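Methoxy for fluoro next to the benzothiazole: solubility expectation

This account rests on a few compounds, and the source may have more. Where it says the series, first, only, none or still open, it means among the compounds named here.

Measured compounds in a physicochemical assay for solubility, read by spectrophotometry, in phosphate buffer, measured as kinetic solubility, with a stated time of 18 h, at pH 7.4; a higher number here means a more soluble compound, a lower number a less soluble compound:
compound 1, `COc1cc(Cl)c(C(=O)Nc2cccc(-c3nc4ccccc4s3)c2)cc1[N+](=O)[O-]`, 10 nM
compound 2, `O=C(Nc1cccc(-c2nc3ccccc3s2)c1)c1cc([N+](=O)[O-])ccc1Cl`, 580 nM
compound 3, `O=C(Nc1ccc(F)c(-c2nc3ccccc3s2)c1)c1cc([N+](=O)[O-])ccc1Cl`, 490 nM

Compound 3 stands second highest of the three numbers. Its nearest neighbour is compound 2, with a 1.2-fold lower number from compound 2 to compound 3 (0.07 log units; within the scatter) between them; its furthest is compound 1, which gives a far lower number, and that gap lies well beyond the scatter.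

Compound 4, `COc1ccc(NC(=O)c2cc([N+](=O)[O-])ccc2Cl)cc1-c1nc2ccccc2s1`, differs from compound 3 in one place: methoxy in place of fluoro on an aromatic carbon.

Within the data shown here, two measured steps bear on this. The step from compound 2 to compound 3 put a fluoro onto the same ring, and it gave a 1.2-fold lower number from compound 2 to compound 3 (0.07 log units; within the scatter), so the fluoro itself carries little weight. Among the measured compounds shown here, the step from compound 1 to compound 2 removed a methoxy, and it gave a 58-fold higher number from compound 1 to compound 2 (1.76 log units; beyond the scatter); that methoxy sat on the other aromatic ring of the shared core, so the match to compound 4 is only partial, and no measured pair shows a methoxy on the ring that carries the benzothiazole.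

Because of a 58-fold higher number from compound 1 to compound 2 (1.76 log units; beyond the scatter), a methoxy entering is expected to lower the number in this assay, and because of a 1.2-fold lower number from compound 2 to compound 3 (0.07 log units; within the scatter), losing the fluoro is expected to matter little. For compound 4 the expected step is therefore a 3.3-fold lower number from compound 3 to compound 4 (0.51 log units; beyond the scatter), downward but smaller than the change seen on the other ring, given the different place. Compound 4 is estimated at 150 nM, within 40 nM to 500 nM.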

Compound 4, solubility: 260 nM
The estimate for compound 4 lay 1.7-fold (0.24 log units) below the measured number; the measured number falls inside the stated range.
By their numbers in this assay, from the lowest: compound 1; then compounds 4, 3 and 2 (each within the scatter of the next, the first and the last beyond it).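

At this position, ortho to a 1,3-benzothiazol-2-yl group and para to a large group, exchanging fluoro for methoxy gives a 1.9-fold lower number from compound 3 to compound 4 (0.28 log units; within the scatter) in this assay, so the two groups cannot be told apart here. Among these compounds, the comparison with hydrogen gives the first measured reading of a methoxy on this ring: a 2.2-fold lower number from compound 2 to compound 4 (0.35 log units; beyond the scatter) is a modest step, though one that lies beyond the scatter. Set against a 58-fold higher number from compound 1 to compound 2 (1.76 log units; beyond the scatter), the step for a methoxy on the other aromatic ring of the shared core, this shows that the size of a methoxy step in this assay is not the same at the two places, and that the large step seen earlier does not carry over to this position.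

On these data alone, it remains open how a group of another kind at this position, such as an amine, a carboxylic acid or a longer chain like butoxy, would read in this assay, and whether a methoxy on both rings would read as either single change does. Nothing available gives a reason for the difference between the two places.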